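This account rests on a few compounds, and the source may have more. Where it says the series, first, only, none or still open, it means among the compounds named here.

Measured so far in an ADME assay on the whole organism (plasma) for pharmacokinetics, with Rattus norvegicus as the target, with a stated time of 6 h, at a dose of 10 mg/kg by the oral route; a higher number here means more compound in the circulation at the dose given, a lower number less compound in the circulation:
- compound 1 `O=C(O)c1ccc(CS(=O)(=O)N2CCN(c3cnn(-c4cccc(Cl)c4)c(=O)c3OC3CCCC3)CC2)cc1`: 130 ng.h/mL
- compound 2 `Nc1cccc(CS(=O)(=O)N2CCN(c3cnn(-c4cccc(Cl)c4)c(=O)c3OC3CCCC3)CC2)c1`: 50 ng.h/mL

Of these two numbers, compound 2 has the lower, at 50 ng.h/mL on the same oral dose. Compound 3 `Nc1ccc(CS(=O)(=O)N2CCN(c3cnn(-c4cccc(Cl)c4)c(=O)c3OC3CCCC3)CC2)cc1` is the next to be read in this assay and keeps the shared core of compound 2. The change is 4-aminophenyl in place of 3-aminophenyl on a saturated chain carbon bound to a sulfonyl sulfur, counted as 4-aminophenyl in place of 3-aminophenyl on a saturated chain carbon bound to a sulfonyl sulfur with the same atoms joined differently.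

For the measured compounds named here, only one measured step bears on this, and only loosely. It is a 2.6-fold lower number from compound 1 to compound 2 (0.41 log units; beyond the scatter) and it replaces 4-carboxyphenyl with 3-aminophenyl, so it changes the group and its place together. Going by the values given here, no measured pair isolates the move of the amino group alone, so neither direction is favoured by the data. No step beyond the scatter is therefore expected, and the estimate stays close to compound 2. The expected step is a 1.2-fold higher number from compound 2 to compound 3 (0.08 log units; within the scatter) and remains uncertain. For compound 3 the estimated value is 60 ng.h/mL in an expected range from 20 ng.h/mL to 180 ng.h/mL on this reading.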

Compound 3, area under the concentration-time curve: 80 ng.h/mL
The estimate for compound 3 lay 1.3-fold (0.12 log units) below the measured number; low and high end bracket the measured number.
By their numbers in this assay, from the lowest: compounds 2, 3 and 1 (each within the scatter of the next, the first and the last beyond it).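

Moving the amino group alone in this assay gives (a 1.6-fold higher number from compound 2 to compound 3 (0.20 log units; within the scatter)), so on a saturated chain carbon bound to a sulfonyl sulfur, this assay does not tell 4-aminophenyl from 3-aminophenyl. Amino in place of carboxy on an aromatic carbon, with nothing else altered, gives (a 1.6-fold lower number from compound 1 to compound 3 (0.21 log units; within the scatter)), so this exchange is not separated from the scatter either, whereas the earlier step that changed the group and its place together gives (a 2.6-fold lower number from compound 1 to compound 2 (0.41 log units; beyond the scatter)) and remains the only step beyond it. No measurement is available that would explain any of these numbers.

Still open, going by these compounds, is how the gap between compound 1 and compound 2 divides between the identity of the group and its place, a question that a 3-carboxyphenyl group on the same chain carbon would address directly. Also open, on these data alone, is whether a nitrile or a primary amide on the aromatic ring, or a longer chain carrying the sulfonyl sulfur, would give a step beyond the scatter in this assay from any of the three compounds.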